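The source may hold more compounds than are shown below. What is called first, only, known or untested is meant among the compounds shown, and "the series" means these compounds.

Measured compounds in an in vitro ADME assay on microsomes from liver (Homo sapiens) for metabolic stability, read by LC-MS; a higher number here means that the compound lasts longer, a lower number that the compound disappears faster:
compound 1, `CCCCc1ccc(NC(=O)N2CCCN(C(=O)CCC3CCCC3)CC2)cc1`, half-life 0.0833 h
compound 2, `O=C(CCC1CCCC1)N1CCCN(C(=O)Nc2ccccc2)CC1`, half-life 0.05 h
compound 3, `CC(C)(C)c1ccc(NC(=O)N2CCCN(C(=O)CCC3CCCC3)CC2)cc1`, half-life 0.05 h

Compound 3 stands level with compound 2 at the digits shown, the two together giving the lowest numbers of the three, but the step of no change at the digits printed from compound 2 to compound 3 (within the scatter) and the step of a 1.7-fold lower number from compound 1 to compound 3 (0.22 log units; within the scatter) both lie within the scatter, so no ordering among the three can be claimed in this assay.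

Compound 4, `CC(C)CCC(=O)N1CCCN(C(=O)Nc2ccc(C(C)(C)C)cc2)CC1`, differs from compound 3 at the other end of the shared core: isopropyl in place of cyclopentyl on a saturated chain carbon, two bonds along the chain from a carbonyl carbon. Within the data shown here, none of the measured steps touches this position. All three steps, a 1.7-fold lower number from compound 1 to compound 2 (0.22 log units; within the scatter), a 1.7-fold lower number from compound 1 to compound 3 (0.22 log units; within the scatter) and no change at the digits printed from compound 2 to compound 3 (within the scatter), change the group on the aromatic carbon and all stay within the scatter. Among the measured compounds shown here, the series therefore gives no direct precedent for this change, only the observation that every variation tried so far has left the half-life in this assay unmoved beyond the scatter, with all three numbers sitting close together. On that basis no step beyond the scatter is expected for compound 4, though the uncertainty is wide. For compound 4 the expected step is a 1.2-fold higher number from compound 3 to compound 4 (0.08 log units; within the scatter). Compound 4 is thus estimated at 0.06 h in this assay, with a range from 0.025 h to 0.15 h.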

Compound 4, half-life: 0.05 h
For compound 4 the middle estimate is 1.2-fold (0.08 log units) above the measured one, and the stated range covers the measured number.
By their numbers in this assay, from the lowest: compounds 2, 3, 4 and 1 (each within the scatter of the next).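

In this assay, the only step shown at this position, isopropyl in place of cyclopentyl on a saturated chain carbon, two bonds along the chain from a carbonyl carbon, reads no change at the digits printed from compound 3 to compound 4 (within the scatter). Among these compounds, the earlier steps all changed the group on the aromatic carbon, so this is the sole reading for the other end of the shared core, and it shows that going from a five-membered non-aromatic ring of carbon only, with 5 heavy atoms, to an open group with 3 heavy atoms does not move the half-life beyond the scatter when tert-butyl stays on the aromatic carbon. No measured information bears on why the half-life responds in this way.

Still open, on these data alone, is whether an amine or a carboxylic acid at this place on the chain, groups of a different kind from the two carbon-only ones compared here, would give a step beyond the scatter. Also open, as far as these compounds go, is whether the same exchange of cyclopentyl for isopropyl reads alike with butyl or hydrogen on the aromatic carbon.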